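A few compounds are considered here, and "the series" means these few. Any claim that something is new, unique, unknown or untested is made for them only; others in the source may bear on it.

Of the compounds shown here, three that share one core have so far been tested in a functional assay on EKVX cells (Homo sapiens) for inhibition, read by sulforhodamine B assay, with a stated time of 48 h, tested at 10 uM (a lower number here means less inhibition of growth, a higher number more inhibition of growth at the concentration tested), and give a first view of the series. Compound 1 `COc1ccc(-c2nc3sc(-c4ccccc4)cn3n2)cc1` gives 37% in this test, compound 3 `Clc1ccc(-c2cn3nc(-c4ccccc4)nc3s2)cc1` gives 28% and compound 2 `COc1cc(-c2nc3sc(-c4ccccc4)cn3n2)cc(OC)c1OC` gives 63% there. Compound 1 thus lies within the scatter of compound 3, while compound 2 stands above compound 1 by a margin beyond the scatter.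

The next compound, compound 4 `COc1ccc(-c2nc3sc(-c4ccc(Cl)cc4)cn3n2)cc1`, has not yet been measured in this assay and departs from compound 1 in one place. Its phenyl becomes 4-chlorophenyl: chloro in place of hydrogen on an aromatic carbon (chloro in place of hydrogen on an aromatic carbon, para to a large group). Within the data shown here, no two measured compounds differ in only one place, so the data offer no direct measure of this change. The expectation therefore starts from compound 1 at 37% and foresees no step beyond the scatter in either direction, though with wide uncertainty. The estimated change, a number 1 percentage points lower from compound 1 to compound 4 (within the scatter), is expected to remain within the usual scatter. For compound 4 the expected value is 36%, with an estimated range from 16% to 56% in this test.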

Compound 4, percent growth inhibition at one concentration: 52.5%
For compound 4 the middle estimate is 16.5 percentage points below the measured one; the measured number falls inside the stated range.
By their numbers in this assay, from the lowest: compounds 3 and 1 (each within the scatter of the next); then compound 4; then compound 2.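

In this assay, among these compounds, chloro in place of hydrogen on an aromatic carbon, para to a large group, gives the first step that can be read directly, a number 15.5 percentage points higher from compound 1 to compound 4 (beyond the scatter), so this position on the phenyl ring responds to substitution rather than tolerating it without effect. The second step, a number 24.5 percentage points higher from compound 3 to compound 4 (beyond the scatter), comes from a methoxy group that takes the place of a hydrogen and shows that, with the 4-chlorophenyl held constant, adding this group also raises growth inhibition, so compound 4, which carries both groups, stands above each of the two compounds that lack one of them. Nothing available explains either step, and the size of each is all that can be stated.

The compounds shown leave open whether this rise belongs to chloro itself or would also appear with fluoro, methyl, an amine or a carboxylic acid at the same position. They also leave open whether chloro at this position would change the number of compound 2, which carries three methoxy groups, in the same direction.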